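Swapping an Aryl Ring on a Fused Core, Cytotoxicity Expected

A few compounds are considered here, and "the series" means these few. Any claim that something is new, unique, unknown or untested is made for them only; others in the source may bear on it.

This account follows a single change on a shared core. Compound 1 `Cc1nc(C)c(C(=O)Nc2ccc(F)c(-c3nc4ncc(-c5cccnc5Cl)cn4n3)c2)o1` was tested in an ADME assay on HepG2 cells (Homo sapiens) for cytotoxicity, read by resazurin assay, with a stated time of 48 h; a lower number here means that less compound is needed, a higher number that more compound is needed for the effect. In this assay compound 1 gives only the limit > 50000 nM. Compound 3 `Cc1nc(C)c(C(=O)Nc2ccc(F)c(-c3nc4ncc(-c5ccccc5Cl)cn4n3)c2)o1` also returns only the limit > 50000 nM. The step that the two limits leave unreadable from compound 1 to compound 3 is therefore not readable. Compound 2 `O=C(Nc1ccc(F)c(-c2nc3ncc(-c4cncc(F)c4)cc3[nH]2)c1)N1CCCC1`, the starting point here, likewise gives only the limit > 50000 nM, so its standing on the numbers is no more than the limit of > 50000 nM in this assay, at which 3 of the 3 values shown sit.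

Compound 4 `O=C(Nc1ccc(F)c(-c2nc3ncc(-c4ccc(F)cc4F)cc3[nH]2)c1)N1CCCC1` differs from compound 2 by 2,4-difluorophenyl in place of 5-fluoropyridin-3-yl on an aromatic carbon. Going by the values given here, no measured step reads on this change: the only pair that differs in one place, compound 1 to compound 3, swaps one aromatic ring for another and sits at the limit on both sides, and all three measured compounds sit at that limit. There is thus no evidence for a step in either direction beyond the scatter, and the expectation is that compound 4 will again reach the limit rather than a number. Compound 4 is accordingly estimated at 50000 nM, between 20000 nM and 120000 nM, which is expected to be a step of a number no higher from compound 2 to compound 4 (the limit leaves the size open).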

Compound 4, half-maximal effective concentration: 32400 nM
Beside the measured number, compound 4's estimate is 1.5-fold (0.19 log units) above it, within the range that was stated.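

Compound 4 is the only compound shown in this assay that gives a number rather than a limit, at 32400 nM. Unlike the ring swap between compound 1 and compound 3, which cannot be read, placing 2,4-difluorophenyl on this aromatic carbon in place of 5-fluoropyridin-3-yl gives an at least 1.5-fold lower number from compound 2 to compound 4 (0.18 log units; that floor lies within the scatter), so a compound with a change at this position can give a number in the tested range, although the floor of the step does not by itself show a change beyond the scatter. The true size of the step stays unknown because compound 2 carries only a limit: the limit of > 50000 nM in this assay, at which 3 of the 4 values shown sit.

The compounds shown leave open whether the number follows from the loss of the ring nitrogen or from the two fluorine atoms, since this change alters both at once. They also do not tell how a phenyl ring carrying an amine or a carboxylic acid, or a morpholine ring, would read at this position in this assay, or whether the same swap on the core of compound 1 would give a number.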